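The source may report more compounds than this note shows. Statements on the series, on what has been measured and on what is new or still open speak of the compounds shown alone.

Three related amides share one core, and two of them have numbers. Compound 1 `O=C(Nc1ccccc1)c1ccc(-c2ncccc2C(F)(F)F)cc1` stands at "not determined" (no result reported) in a functional assay for antagonist activity at transient receptor potential cation channel subfamily V member 1 (Rattus norvegicus) (a lower number here means a stronger inhibitor, a higher number a weaker inhibitor), so it has no result there. Compound 2 `Cc1cccnc1-c1ccc(C(=O)Nc2ccc(Cl)cc2)cc1` gives 2020 nM in this assay. Compound 3 `CC(C)(C)c1ccc(NC(=O)c2ccc(-c3ncccc3F)cc2)cc1` gives 1 nM in this assay, the lowest of the two numbers and far away from compound 2, a gap well beyond the usual scatter. Nothing here links the structures of compound 2 and compound 3 by a single change, so their two numbers can only be set side by side.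

Compound 4 `CC(C)(C)c1ccc(NC(=O)c2ccc(-c3ncccc3C(=O)O)cc2)cc1` is the next one to be tested. It differs from compound 3 in one spot: carboxy in place of fluoro on an aromatic carbon The new group sits on an aromatic carbon of a six-membered aromatic ring with 1 nitrogen, ortho to a large group and two atoms from the ring nitrogen.

Going by the values given here, with no measured step of this kind to lean on, only a guess is possible: a large move towards a higher number, meaning weaker inhibition, is expected for a 300-fold higher number from compound 3 to compound 4 (2.48 log units; beyond the scatter), with a wide band around it. Compound 4 is therefore estimated at 300 nM, somewhere between 20 nM and 5000 nM.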

Compound 4, half-maximal inhibitory concentration: 560 nM
The estimate for compound 4 lay 1.9-fold (0.27 log units) below the measured number; the measured number falls inside the stated range.
By their numbers in this assay, from the lowest: compound 3; then compound 4; then compound 2.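

Going by these compounds alone, this is the first change at this position that can be read directly, on an aromatic carbon ortho to a large group and two atoms from the ring nitrogen. In this assay carboxy in place of fluoro gives (a 560-fold higher number from compound 3 to compound 4 (2.75 log units; beyond the scatter)), a large step beyond the usual scatter, so with the rest of the molecule held fixed, inhibition depends strongly on the group at this spot. No measurement shown here bears on why the number rises so far.

One step cannot separate the carboxylic acid itself from any other group of similar size, and a methyl ester, a primary amide or an amine at this position would test that. Compound 1 has no result and compound 2 differs from compound 3 in more than one place, so neither helps settle this.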